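Working notes: the step from compound 3 to compound 4

The source may hold more compounds than are shown below. What is called first, only, known or untested is meant among the compounds shown, and "the series" means these compounds.

Measured in an ADME assay on HEK293 cells (Homo sapiens) for cytotoxicity, with a stated time of 72 h; on this read-out higher numbers stand for an effect only at larger amounts of compound and lower numbers for an effect already at smaller amounts:
- compound 1 `C=C[C@@](C)(/C=C/c1ccc(O)cc1)CCC=O`: > 36600 nM (a limit)
- compound 2 `C=C[C@@](C)(/C=C/c1ccc(O)cc1)CC/C=C/C(=O)OCC`: > 36600 nM (a limit)
- compound 3 `C=C[C@@](C)(/C=C/c1ccc(O)cc1)CC/C=C/C#N`: > 36600 nM (a limit)

Compound 3 stands at > 36600 nM, and this is a limit rather than a number. It shares that position with the other two compounds: the limit of > 36600 nM in this assay, at which 3 of the 3 values shown sit.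

The next compound is compound 4 `C=C[C@@](C)(/C=C/c1ccc(O)cc1)CC/C=C(C)/C=N/N`. The change from compound 3 is a group of 6 heavy atoms (4 carbon, 2 nitrogen; no ring) in place of a group of 4 heavy atoms (3 carbon, 1 nitrogen; no ring), on a saturated chain carbon, three bonds along the chain from two double-bonded chain carbons. The replaced group sits on a saturated chain carbon, three bonds along the chain from two double-bonded chain carbons.

Three measured steps changed the group at this same end of the chain: a step that the two limits leave unreadable from compound 1 to compound 2, a step that the two limits leave unreadable from compound 1 to compound 3 and a step that the two limits leave unreadable from compound 2 to compound 3. None of them has a readable size, so none gives a measured step to carry over. No value in the series has yet fallen inside the range of this assay. On that basis, no step beyond the usual scatter is expected, although this expectation is weakly constrained. The expected change is a step that the limit leaves unreadable from compound 3 to compound 4. A further limit is the most likely report. For compound 4 the estimated value is 40000 nM, with an expected range of 15000 nM to 100000 nM.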

Compound 4, half-maximal effective concentration: > 36600 nM
Compound 4: no number, only a limit; the forecaster's own chance of this, stated with the estimate: 75%; the middle value lies beyond the limit too.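

In this assay compound 4 also gives only a limit, so no step can be read between it and compound 1, compound 2 or compound 3, because all four values are limits: the limit of > 36600 nM in this assay, at which 4 of the 4 values shown sit.

The compounds shown leave open whether the groups at this end of the chain differ at all in cytotoxicity, and at what concentration any of the four reaches a half-maximal effect.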